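A few compounds are considered here, and "the series" means these few. Any claim that something is new, unique, unknown or untested is made for them only; others in the source may bear on it.

Measured compounds:
- compound 1 `CC[C@@H](CCn1cncn1)c1ccc(C)cc1`: 69.9 ug/mL
- compound 2 `CCC[C@@H](CCn1cncn1)c1ccc(C)cc1`: 71.3 ug/mL
- compound 3 `CCCC[C@H](CCn1cncn1)c1ccc(Cl)cc1Cl`: 13.4 ug/mL

In an ADME assay on HEp-2 cells (Homo sapiens) for cytotoxicity, read by MTT assay, with a stated time of 3 days (a lower number here means that less compound is tolerated, a higher number that more compound is tolerated), compound 3 gives the lowest of the three numbers; compound 1 stands nearest with a number beyond the scatter above it, and compound 2 furthest, also beyond the scatter. Among the measured compounds shown here, the only single-point step measured so far is a 1.0-fold higher number from compound 1 to compound 2 (0.01 log units; within the scatter), a chain extension that left the read-out unchanged within the scatter; it does not speak to a change in configuration.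

Compound 4 `CCCC[C@@H](CCn1cncn1)c1ccc(Cl)cc1Cl` is the next compound to be measured in this assay. Against compound 3 the change is: the two compounds have the same atoms and bonds and differ only in configuration as drawn: 1 of 1 stereo elements differ; a stereocentre at a saturated chain carbon is drawn R in compound 3 and S in compound 4. For the measured compounds named here, no measured step turns on a stereocentre alone, so there is nothing to scale the expectation from; the two enantiomers of compound 3 are taken to behave alike in this assay unless the measurement shows otherwise. For compound 4 a step of a 1.1-fold higher number from compound 3 to compound 4 (0.05 log units; within the scatter) is expected, that is, no change beyond the scatter. Compound 4 is therefore estimated at 15 ug/mL, within a range from 7 ug/mL to 35 ug/mL.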

Compound 4, half-maximal cytotoxic concentration: 6.5 ug/mL
Beside the measured number, compound 4's estimate is 2.3-fold (0.36 log units) above it; the whole stated range lies above it.
By their numbers in this assay, from the lowest: compound 4; then compound 3; then compounds 1 and 2 (each within the scatter of the next).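

In this assay the stereocentre at a saturated chain carbon makes a measurable difference: going from R to S as drawn gives a 2.1-fold lower number from compound 3 to compound 4 (0.31 log units; beyond the scatter) and so less compound is tolerated. Among the compounds shown here, this is the first step that turns on configuration, and it is modest, whereas the one earlier step, a chain extension, stayed within the scatter. The step can be tied to this stereocentre alone because of the following: the fact that compounds 3 and 4 differ only in the configuration as drawn.

The compounds shown leave open whether the S form as drawn also gives the lower number with a longer chain at this carbon or with the other ring substitution seen in compound 1 and compound 2. They also leave open how the two configurations compare when an amine or a carboxylic acid is carried on the chain.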